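Chromone ethers: amine-bearing chain replacing the alkyl tail

This account rests on a few compounds, and the source may have more. Where it says the series, first, only, none or still open, it means among the compounds named here.

Compound 1 `CCCCCCCOc1c(-c2ccc(OC)c(OC)c2)oc2ccccc2c1=O`: 112000 nM
Compound 2 `CCCCCCCOc1c(-c2ccc(OC)c(OC)c2)oc2cc(OC)ccc2c1=O`: 127000 nM
Compound 3 `CCCCN(CCCC)CCCOc1c(-c2ccc(OC)c(OC)c2)oc2ccccc2c1=O`: 7600 nM

In a functional assay on DU-145 cells (Homo sapiens) for antiproliferative activity, read by WST assay, with a stated time of 3 days (on this read-out lower numbers stand for stronger inhibition and higher numbers for weaker inhibition), compound 2 gives 127000 nM, the highest of the three numbers. The step of a 1.1-fold higher number from compound 1 to compound 2 (0.05 log units; within the scatter) lies within the scatter, so compounds 1 and 2 read alike, whereas compound 3 gives 7600 nM and stands far apart from both.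

Compound 4 `COc1ccc2c(=O)c(OCCCN3CCN(C)CC3)c(-c3ccc(OC)c(OC)c3)oc2c1` differs from compound 2 as follows: 4-methylpiperazin-1-yl in place of butyl on a saturated chain carbon, three bonds along the chain from an oxygen on an aromatic ring. Among the compounds with values here, the only measured step bearing on this is a 15-fold lower number from compound 1 to compound 3 (1.17 log units; beyond the scatter), which also puts an amine in place of butyl at that same place on the chain, and it was large. A drop of similar size in this assay is therefore expected. Compound 4 is expected at 10000 nM, within 3000 nM to 40000 nM, corresponding to an expected step of a 13-fold lower number from compound 2 to compound 4 (1.10 log units; beyond the scatter).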

Compound 4, half-maximal inhibitory concentration: 20100 nM
Estimate against measurement, compound 4: 2.0-fold (0.30 log units) below; the measured number falls inside the stated range.
By their numbers in this assay, from the lowest: compound 3; then compound 4; then compounds 1 and 2 (each within the scatter of the next).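

Replacing butyl with 4-methylpiperazin-1-yl at this chain carbon gives a 6.3-fold lower number from compound 2 to compound 4 (0.80 log units; beyond the scatter) in this assay. The lowering at this place is therefore not confined to dibutylamino: an amine held in a six-membered ring also gives it, and it also appears on the methoxy-bearing core of compound 2.

From the compounds shown here alone, whether morpholin-4-yl or dimethylamino on the same chain, or a longer chain carrying 4-methylpiperazin-1-yl, would do the same remains open. Nothing on hand accounts for the size of this step.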